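Thiophen-3-yl in place of 1,3-thiazol-2-yl: compound 4

A few compounds are considered here, and "the series" means these few. Any claim that something is new, unique, unknown or untested is made for them only; others in the source may bear on it.

In a functional assay on A-375 cells (Homo sapiens) for activation, with a stated time of 3 days (a lower number here means that less compound is needed, a higher number that more compound is needed for the effect), compound 3 `O=C(Nc1ccc(-c2nccs2)cc1)C1CCCN(Cc2ccc(F)c(F)c2)C1` gives 800 nM and compound 2 `O=C(Nc1ccc(-c2cccnc2)cc1)C1CCCN(Cc2ccc(F)c(F)c2)C1` gives 1060 nM, so the two stand within the scatter of each other. Compound 1 `O=C(Nc1ccc(-c2cscn2)cc1)C1CCCN(Cc2cccc(C(F)(F)F)c2)C1` returns only a limit, > 20000 nM, not a number.

Compound 4 `O=C(Nc1ccc(-c2ccsc2)cc1)C1CCCN(Cc2ccc(F)c(F)c2)C1` is the next structure to be read. The change is thiophen-3-yl in place of 1,3-thiazol-2-yl on an aromatic carbon, with thiophen-3-yl in place of 1,3-thiazol-2-yl on an aromatic carbon of a six-membered aromatic ring of carbon only, para to a large group.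

For the measured compounds named here, the one measured step at this place is a 1.3-fold lower number from compound 2 to compound 3 (0.12 log units; within the scatter), and it lies within the scatter. Going by the values given here, this single step is the only guide, so no shift beyond the scatter is expected in this assay, in either direction. The expected change is a 1.1-fold higher number from compound 3 to compound 4 (0.05 log units; within the scatter). For compound 4 the estimated value is 900 nM, with an expected range of 350 nM to 2500 nM.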

Compound 4, half-maximal effective concentration: 1930 nM
Estimate against measurement, compound 4: 2.1-fold (0.33 log units) below, within the range that was stated.
By their numbers in this assay, from the lowest: compounds 3, 2 and 4 (each within the scatter of the next, the first and the last beyond it). At a limit, above all of these: compound 1.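

In this assay, this position now shows its first step beyond the scatter: a 2.4-fold higher number from compound 3 to compound 4 (0.38 log units; beyond the scatter). The step is modest and comes with a ring that has one hetero atom and one hydrogen-bond acceptor in place of a ring with two of each. The position still does not sort cleanly by ring, as a 1.8-fold higher number from compound 2 to compound 4 (0.26 log units; within the scatter), and compound 2 stands within the scatter of both compound 3 and compound 4. Nothing measured here gives a cause for these steps.

Compound 1 returns only a limit, > 20000 nM, and differs from the others in more than one place, so what lies behind that limit stays open. Also open, from the compounds shown here alone, is how this position answers to a ring-bearing amine, a carboxylic acid or a longer chain in place of the five-membered aromatic rings.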